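The source may report more compounds than this note shows. Statements on the series, on what has been measured and on what is new or still open speak of the compounds shown alone.

For the measured compounds named here, compound 1 `CC1(c2ccc(-c3ccccc3C#N)cc2)CC(S(=O)(=O)c2ccc(F)cc2)=C(c2ccc(/C(N)=N\O)cc2)O1` gives 9290 nM in an ADME assay on J774.A1 cells (Mus musculus) for cytotoxicity, read by MTT assay, with a stated time of 72 h (a lower number here means that less compound is tolerated, a higher number that more compound is tolerated), the lowest of the three numbers known; compound 2 `CC1(Cc2ccccc2)CC(S(=O)(=O)c2ccccc2F)=C(c2ccc(/C(N)=N\O)cc2)O1` gives 29100 nM and compound 3 `CC1(Cc2ccccc2)CC(S(=O)(=O)c2ccccc2C(F)(F)F)=C(c2ccc(/C(N)=N\O)cc2)O1` gives 23500 nM, both beyond the scatter above compound 1. Compound 4 `COc1cc(-c2ccc(C3(C)CC(S(=O)(=O)c4ccc(F)cc4)=C(c4ccc(/C(N)=N\O)cc4)O3)cc2)cc(OC)c1OC` differs from compound 1 in one place: 3,4,5-trimethoxyphenyl in place of 2-cyanophenyl on an aromatic carbon. Going by the values given here, the only measured step that differs in one place, a 1.2-fold lower number from compound 2 to compound 3 (0.09 log units; within the scatter), sits elsewhere on the shared core, so none of the measured steps bears on the change to compound 4, and no direction can be read from them. The step to compound 4 is therefore expected to be a 1.0-fold lower number from compound 1 to compound 4 (0.01 log units; within the scatter), without direction beyond the scatter. Compound 4 is estimated at 9000 nM in this assay, within 3000 nM to 27000 nM.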

Compound 4, half-maximal cytotoxic concentration: 5220 nM
Compound 4: middle estimate off by 1.7-fold (0.24 log units), on the high side; measured number inside the range.
By their numbers in this assay, from the lowest: compounds 4 and 1 (each within the scatter of the next); then compounds 3 and 2 (each within the scatter of the next).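

In this assay, the exchange of 2-cyanophenyl for 3,4,5-trimethoxyphenyl on an aromatic carbon para to a large group gives a 1.8-fold lower number from compound 1 to compound 4 (0.25 log units; within the scatter) and is the only step shown at this position. At this position, then, the two aryl groups are not told apart by this read-out, even though the entering group is the larger and carries more hydrogen-bond acceptors. Nothing shown accounts for this result. Going by these compounds, whether an amine or a carboxylic acid on this aromatic carbon would stay within the scatter of compound 1 remains open. So does whether an unsubstituted phenyl would.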